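Fluoro to methyl on the ketone aryl ring

The compounds below may be only part of what the source reports. "The series", "measured", "known", "first", "only" and "open" are said of these compounds alone.

For the measured compounds named here, compound 2 `Cc1cc(C(=O)c2ccccc2F)ccc1OCC(=O)Nc1nc(-c2ccccc2)cs1` is one of two compounds measured in a functional assay on Ehrlich cells (Mus musculus) for cytotoxicity, read by trypan blue exclusion, with a stated time of 48 h (a lower number here means a stronger inhibitor, a higher number a weaker inhibitor), where compound 2 gives 15400 nM; compound 1 `Cc1ccc(C(=O)c2ccc(OCC(=O)Nc3nc(-c4ccccc4)cs3)c(C)c2)cc1` gives 28400 nM, and a 1.8-fold lower number from compound 1 to compound 2 (0.27 log units; within the scatter) lies within the scatter. Compound 3 `Cc1cc(C(=O)c2ccccc2C)ccc1OCC(=O)Nc1nc(-c2ccccc2)cs1` differs from compound 2 by methyl in place of fluoro on an aromatic carbon. Going by the values given here, the only measured step exchanges a different pair of groups, so nothing seen bears directly on this swap, and that one step was itself small. No shift beyond the scatter is therefore expected, and a 1.2-fold higher number from compound 2 to compound 3 (0.07 log units; within the scatter) is an estimate only. Compound 3 is expected to give 18000 nM, within 7000 nM to 45000 nM.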

Compound 3, half-maximal inhibitory concentration: 24300 nM
For compound 3 the middle estimate is 1.4-fold (0.13 log units) below the measured one; the measured number falls inside the stated range.
By their numbers in this assay, from the lowest: compounds 2, 3 and 1 (each within the scatter of the next).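

In this assay, methyl in place of fluoro on this aromatic carbon gives a 1.6-fold higher number from compound 2 to compound 3 (0.20 log units; within the scatter) and so leaves the number within the scatter, as the 2-fluorophenyl and 2-methylphenyl ketones cannot be told apart here. Moving the methyl, with 2-methylphenyl in place of 4-methylphenyl, gives a 1.2-fold lower number from compound 1 to compound 3 (0.07 log units; within the scatter) and likewise shows no separation between these two placements. No supporting measurement bears on these steps.

As far as these compounds go, whether a methoxy, an amine or a carboxylic acid on this ring would move the number beyond the scatter remains open. The compounds shown also leave open how far any change to the shared core would carry.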